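Notes on the amine nitrogen substituent in this series

A few compounds are considered here, and "the series" means these few. Any claim that something is new, unique, unknown or untested is made for them only; others in the source may bear on it.

Compound 1 `CCCCc1ccc(CNC(=O)N(C)C)c(=O)n1Cc1ccc(-c2ccccc2-c2nn[nH]n2)cc1` gives 2 nM in a functional assay (aorta) for antagonist activity, with Oryctolagus cuniculus as the target; a lower number here means a stronger inhibitor, a higher number a weaker inhibitor. Compound 2 `CCCCc1ccc(CNC(C)=O)c(=O)n1Cc1ccc(-c2ccccc2-c2nn[nH]n2)cc1` gives 3 nM in this assay, and compound 3 `CCCCc1ccc(CNS(=O)(=O)c2ccccc2)c(=O)n1Cc1ccc(-c2ccccc2-c2nn[nH]n2)cc1` gives 7 nM. Compound 3 holds the highest of the three numbers in this assay: the nearest is compound 2, reached by a 2.3-fold higher number from compound 2 to compound 3 (0.37 log units; beyond the scatter), the furthest compound 1, reached by a 3.5-fold higher number from compound 1 to compound 3 (0.54 log units; beyond the scatter). Compound 4 `CCCCc1ccc(CN(CC)S(C)(=O)=O)c(=O)n1Cc1ccc(-c2ccccc2-c2nn[nH]n2)cc1` differs from compound 3 by ethyl(methylsulfonyl)amino in place of (phenylsulfonyl)amino on a saturated chain carbon bound to an aromatic carbon. Both measured steps ending at compound 3 concern swaps of the group on this same amine nitrogen and both were modest; the remaining step, a 1.5-fold higher number from compound 1 to compound 2 (0.18 log units; within the scatter), stayed within the scatter. Among the compounds with values here, no measured step removes a hydrogen-bond donor or exchanges an aromatic ring for a methyl and an ethyl, so the direction is open. A step of modest size at most is expected, a 1.1-fold higher number from compound 3 to compound 4 (0.06 log units; within the scatter), with no clear sign. Compound 4 is therefore estimated at 8 nM in this assay, within 2.5 nM to 25 nM.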

Compound 4, half-maximal inhibitory concentration: 2 nM
Compound 4: the middle estimate sits 4.0-fold (0.60 log units) above what was measured; measured number below the stated range.
By their numbers in this assay, from the lowest: compounds 1, 4 and 2 (each within the scatter of the next); then compound 3.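

In this assay a sulfonyl group on this amine nitrogen does not by itself go with the higher number: ethyl(methylsulfonyl)amino in place of (phenylsulfonyl)amino gives a 3.5-fold lower number from compound 3 to compound 4 (0.54 log units; beyond the scatter) and closes the gap seen for compound 3. Compound 4 carries no hydrogen-bond donor in this group yet stands level with the two carbonyl-bearing groups, as the steps of a 1.5-fold lower number from compound 2 to compound 4 (0.18 log units; within the scatter) and no change at the digits printed from compound 1 to compound 4 (within the scatter) both show. No measurement in hand accounts for these steps.

The change to compound 4 swaps phenyl for methyl and the nitrogen hydrogen for ethyl together, so the share of each remains unresolved; (methylsulfonyl)amino and ethyl(phenylsulfonyl)amino would separate them. On these data alone, how a free amine or a carboxylic acid at this place would read in this assay also remains open.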